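A Pyridine Ester in Place of a Chloroacetyl Group

The source may hold more compounds than are shown below. What is called first, only, known or untested is meant among the compounds shown, and "the series" means these compounds.

The shared core carries an ester, and in a functional assay on NCI-H460 cells (Homo sapiens) for cytotoxicity, read by MTT assay, with a stated time of 48 h (a lower number here means a stronger inhibitor, a higher number a weaker inhibitor), compound 1 `C=C1C(=O)O[C@H]2CC3=C[C@H](C/C(C)=C/[C@@H](OC(=O)c4ccc(-c5ccccc5)cc4)[C@H]12)OC3=O` gives 3500 nM while compound 2 `C=C1C(=O)O[C@H]2CC3=C[C@H](C/C(C)=C/[C@@H](OC(=O)/C=C/c4ccc(C(F)(F)F)cc4)[C@H]12)OC3=O` gives 1400 nM. Compound 3 `C=C1C(=O)O[C@H]2CC3=C[C@H](C/C(C)=C/[C@@H](OC(=O)CCl)[C@H]12)OC3=O` reaches only the limit of this assay, > 10000 nM, a limit and not a number (the limit of > 10000 nM in this assay, at which 1 of the 3 values shown sits). Compound 4 `C=C1C(=O)O[C@H]2CC3=C[C@H](C/C(C)=C/[C@@H](OC(=O)c4ccncc4)[C@H]12)OC3=O` differs from compound 3 by pyridin-4-yl in place of chloromethyl on a carbonyl carbon. For the measured compounds named here, no measured step covers this change. Compound 1 also carries an aromatic ring on the carbonyl and gives 3500 nM, and compound 2 gives 1400 nM, so an aromatic ester is seen here with values inside the measured range. The expected step is an at least 2.0-fold lower number from compound 3 to compound 4 (0.30 log units; that floor lies within the scatter), a gain in potency rather than none beyond the scatter. In this assay compound 4 is estimated at 5000 nM, between 2000 nM and 15000 nM.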

Compound 4, half-maximal inhibitory concentration: 5600 nM
Estimate against measurement, compound 4: 1.1-fold (0.05 log units) below; measured number inside the range.
By their numbers in this assay, from the lowest: compound 2; then compounds 1 and 4 (each within the scatter of the next). At a limit, above all of these: compound 3.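

In this assay, pyridin-4-yl in place of chloromethyl on a carbonyl carbon gives an at least 1.7-fold lower number from compound 3 to compound 4 (0.25 log units; that floor lies within the scatter), the first step read at this position. Compound 4 shows that an aromatic ring with a hetero atom in this place gives a number rather than a limit. Compound 3 remains at a limit and not a number, so this step is only a floor and its full size cannot be read: the limit of > 10000 nM in this assay, at which 1 of the 4 values shown sits.

On these data alone, what stays open is how a plain phenyl ring on this carbonyl carbon would compare with pyridin-4-yl. Also open, as far as these compounds go, is what a longer chain ending in an amine would give here.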